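Removing the butyl chain from compound 2

The source may hold more compounds than are shown below. What is called first, only, known or untested is meant among the compounds shown, and "the series" means these compounds.

In a functional assay on NCI-H1975 cells (Homo sapiens) for antiproliferative activity, read by CCK-8 assay, with a stated time of 72 h (on this read-out higher numbers stand for weaker inhibition of growth and lower numbers for stronger inhibition of growth), compound 2 `CCCCNC(=O)c1ccc2c(ccn2-c2ncc3c(n2)N(c2ccn(C)n2)C(CC)C(=O)N3C)c1` gives 12000 nM. Compound 1 `CCCNC(=O)c1ccc2c(ccn2-c2ncc3c(n2)N(c2ccn(C)n2)C(CC)C(=O)N3C)c1` gives 11000 nM, so the two stand level within the usual scatter. Compound 3 `CC[C@@H]1C(=O)N(C)c2cnc(-n3ccc4cc(C(=O)NC5CCCC5)ccc43)nc2N1C1CCCC1` gives 856 nM, a clearly lower number, but it differs from compound 2 in more than one place, so it cannot isolate the change considered here.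

That change leads to compound 4 `CCC1C(=O)N(C)c2cnc(-n3ccc4cc(C(N)=O)ccc43)nc2N1c1ccn(C)n1`, and the computed difference reads (hydrogen in place of butyl on an amide-type nitrogen). In words, hydrogen stands in place of butyl on an amide-type nitrogen, so butylcarbamoyl becomes carbamoyl.

Going by the values given here, only one measured step bears on this, the chain change on that same nitrogen: a 1.1-fold higher number from compound 1 to compound 2 (0.04 log units; within the scatter). Adding one carbon to the chain left the number inside the scatter. However, no measured compound lacks the chain altogether, so compound 4 goes beyond what has been tested, and any expectation must stay wide. Among the compounds with values here, with only that flat step from compound 1 to compound 2 as a guide, no clear shift is expected in this assay. The expected outcome is a 1.3-fold lower number from compound 2 to compound 4 (0.12 log units; within the scatter), a step no larger than the scatter. For compound 4 the estimated value is 9000 nM, with an expected range from 3000 nM to 25000 nM.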

Compound 4, concentration for 50% growth inhibition: "not active" (no number reported)
Compound 4 has no reported number here; there is nothing to compare the estimate with.
By their numbers in this assay, from the lowest: compound 3; then compounds 1 and 2 (each within the scatter of the next).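

In this assay, going by these compounds alone, compound 4 carries only the remark "not active", with no number, and no step from compound 2 to compound 4 can be read. The compounds shown leave open how far the number for compound 4 would stand from that of compound 2 once butyl gives way to hydrogen. No measurement shown offers an explanation for this result.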